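A Chloro-Cyano Phenyl Variant in a Cytotoxicity Series

This account rests on a few compounds, and the source may have more. Where it says the series, first, only, none or still open, it means among the compounds named here.

Of the compounds shown here, three built on one shared core have been tested in an ADME assay on C8166 cells (Homo sapiens) for cytotoxicity, read by MTT assay; a lower number here means that less compound is tolerated, a higher number that more compound is tolerated. Compound 1 `Cc1cc(S(N)(=O)=O)ccc1NC(=O)COc1ccc(Cl)cc1C(O)c1ccccc1` gives 33400 nM in this assay. Compound 2 `Cc1cc(S(N)(=O)=O)ccc1NC(=O)COc1ccc(Cl)cc1C(O)c1cccc([N+](=O)[O-])c1` gives 36900 nM, and compound 3 `Cc1ccc(C(O)c2cc(Cl)ccc2OCC(=O)Nc2ccc(S(N)(=O)=O)cc2C)c(C)c1` gives 26400 nM. Compound 1 stands in the middle of the three numbers, though none of the gaps is meaningful: a 1.1-fold higher number from compound 1 to compound 2 (0.04 log units; within the scatter), and a 1.3-fold lower number from compound 1 to compound 3 (0.10 log units; within the scatter). Compounds 2 and 3 likewise sit together, since a 1.4-fold lower number from compound 2 to compound 3 (0.15 log units; within the scatter).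

Compound 4 `Cc1cc(S(N)(=O)=O)ccc1NC(=O)COc1ccc(Cl)cc1C(O)c1cc(Cl)cc(C#N)c1` has not yet been measured in this assay. It differs from compound 1 in one place: 3-chloro-5-cyanophenyl in place of phenyl on a saturated chain carbon bound to an aromatic carbon and an oxygen on a saturated carbon. Going by the values given here, two measured steps bear on this change. Both also swap the group on a saturated chain carbon bound to an aromatic carbon and an oxygen on a saturated carbon. The first is a 1.1-fold higher number from compound 1 to compound 2 (0.04 log units; within the scatter); the second is a 1.3-fold lower number from compound 1 to compound 3 (0.10 log units; within the scatter). Neither of these substitutions moved the number beyond the scatter, so no step beyond the scatter is expected for compound 4 either, with a 1.1-fold lower number from compound 1 to compound 4 (0.03 log units; within the scatter) as the estimated change. Compound 4 is therefore expected to give about 31000 nM in this assay, within an estimated range from 15000 nM to 62000 nM.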

Compound 4, half-maximal cytotoxic concentration: 31600 nM
The estimate for compound 4 lay 1.0-fold (0.01 log units) below the measured number; low and high end bracket the measured number.
By their numbers in this assay, from the lowest: compounds 3, 4, 1 and 2 (each within the scatter of the next).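

In this assay, the position on a saturated chain carbon bound to an aromatic carbon and an oxygen on a saturated carbon also accepts a larger group with two substituents: 3-chloro-5-cyanophenyl in place of phenyl brings in a chlorine and a nitrile, yet gives a 1.1-fold lower number from compound 1 to compound 4 (0.02 log units; within the scatter) and so adds no step beyond the scatter. The earlier compounds showed this only for a single nitro group and for two methyl groups, and the new group sits no further from either of them, with a 1.2-fold lower number from compound 2 to compound 4 (0.07 log units; within the scatter) for the nitro case and a 1.2-fold higher number from compound 3 to compound 4 (0.08 log units; within the scatter) for the dimethyl case, so all four aromatic groups shown at this position remain within the scatter on every listed step. Nothing measured here explains why the number holds so steady across these groups.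

Every compound shown keeps a six-membered aromatic ring of carbon at this position, so what an amine, a carboxylic acid or a longer chain would do there stays open. From the compounds shown here alone, whether a change elsewhere on the shared core would move the number beyond the scatter also stays open.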